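The source may hold more compounds than are shown below. What is called first, only, known or untested is meant among the compounds shown, and "the series" means these compounds.

Measured compounds:
- compound 1 `COc1ccc(/C=C\c2cc(OC)c(OC)c(OC)c2)cc1OCc1ccc(CN2CC[C@H](C(=O)O)C2)cc1` — in an ADME assay on HEK293 cells (Homo sapiens) for cytotoxicity, read by CCK-8 assay, with a stated time of 48 h (on this read-out lower numbers stand for stronger inhibition and higher numbers for weaker inhibition), compound 1 gives > 50000 nM, which is a limit of the assay rather than a number.
- compound 2 `COc1ccc(/C=C\c2cc(OC)c(OC)c(OC)c2)cc1OCc1ccc(CN2CCCC[C@H]2C(=O)O)cc1` — compound 2 gives > 50000 nM, again a limit.
- compound 3 `COc1ccc(/C=C\c2cc(OC)c(OC)c(OC)c2)cc1OCc1ccc(CN2CC[C@H](O)C2)cc1` — compound 3 gives > 50000 nM, also a limit.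

Within the data shown here, compound 3 therefore stands at the limit where all three values sit (the limit of > 50000 nM in this assay, at which 3 of the 3 values shown sit); no measured compound is separated from it by a readable number. The three single-point changes among the measured compounds, a step that the two limits leave unreadable from compound 1 to compound 2, a step that the two limits leave unreadable from compound 1 to compound 3 and a step that the two limits leave unreadable from compound 2 to compound 3, are all unreadable for the same reason.

Compound 4 `COc1ccc(/C=C\c2cc(OC)c(OC)c(OC)c2)cc1OCc1ccc(CNCCN(C)C)cc1` differs from compound 3 by (2-(dimethylamino)ethyl)amino in place of 3-hydroxypyrrolidin-1-yl on a saturated chain carbon bound to an aromatic carbon. Among the measured compounds shown here, none of the measured steps bears a size on this change, since every value is a limit (the limit of > 50000 nM in this assay, at which 3 of the 3 values shown sit). No step beyond the scatter is expected in this assay, in either direction, and a limit is the most likely outcome again. Compound 4 is estimated at 60000 nM, with a range of 20000 nM to 150000 nM, an expected step that the limit leaves unreadable from compound 3 to compound 4.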

Compound 4, half-maximal inhibitory concentration: 39000 nM
Compound 4: middle estimate off by 1.5-fold (0.19 log units), on the high side; the measured number falls inside the stated range.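

In this assay, among these compounds, compound 4 gives 39000 nM, the first real number for a group on this saturated chain carbon bound to an aromatic carbon. Its steps from the three compounds at the limit are an at least 1.2-fold lower number from compound 3 to compound 4 (0.10 log units; that floor lies within the scatter), an at least 1.2-fold lower number from compound 2 to compound 4 (0.10 log units; that floor lies within the scatter) and an at least 1.2-fold lower number from compound 1 to compound 4 (0.10 log units; that floor lies within the scatter), so the (2-(dimethylamino)ethyl)amino group gives a measurable value, but no step is shown to lie beyond the scatter. The steps among compound 1, compound 2 and compound 3 still cannot be read, as their values are all limits: the limit of > 50000 nM in this assay, at which 3 of the 4 values shown sit.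

Still open, as far as these compounds go, is which feature of the change goes with the measurable value: the missing ring or the second nitrogen. A 4-methylpiperazin-1-yl group, which keeps both nitrogens within a ring, or a longer chain between the two nitrogens would help to separate the two.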